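Cytotoxicity notes on a thiazole amide series

The compounds below may be only part of what the source reports. "The series", "measured", "known", "first", "only" and "open" are said of these compounds alone.

Compound 1 `O=C(Nc1ncc(Cc2ccc(Br)cc2)s1)c1cccs1` in an ADME assay on HepG2 2.2.15 cells (Homo sapiens) for cytotoxicity (a lower number here means that less compound is tolerated, a higher number that more compound is tolerated), gives a value of > 50000 nM, which is a limit of the measurement rather than a number. Compound 2 `CC(C)(C)OC(=O)Nc1ncc(C(Oc2ccc(OCc3ccccc3)cc2)c2ccc(Cl)cc2)s1` in this assay likewise gives > 50000 nM, again a limit. Compound 3 `O=C(Nc1ncc(C(OCc2ccc(Cl)cc2)c2ccccc2)s1)c1cccs1` in this assay is recorded as "not toxic" (no number reported), with no number attached; it therefore cannot be placed against the other two beyond noting that both of those sit at the limit of > 50000 nM in this assay, at which 2 of the 3 values shown sit. Compound 4 `COc1ccc(Br)c(COC(c2ccccc2)c2cnc(NC(=O)c3cccs3)s2)c1` is not yet measured. It differs from compound 3 by 2-bromo-5-methoxyphenyl in place of 4-chlorophenyl on a saturated chain carbon bound to an oxygen on a saturated carbon. Within the data shown here, no measured step between compounds exists here to size this change, so no shift beyond the scatter in this assay is expected, and a result at the limit again seems likely. Compound 4 is estimated at 60000 nM, within 25000 nM to 150000 nM.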

Compound 4, half-maximal cytotoxic concentration: "not toxic" (no number reported)
Compound 4 has no reported number here; no gap can be computed for the estimate.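

Compound 3 and compound 4 are both recorded only as "not toxic" in this assay, so no step can be read between them. The compounds shown leave open whether 2-bromo-5-methoxybenzyl in place of 4-chlorobenzyl changes cytotoxicity at all, and the only reference remains a limit: the limit of > 50000 nM in this assay, at which 2 of the 4 values shown sit.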